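Adding a Methyl to the Benzoxazole Ring

The compounds below may be only part of what the source reports. "The series", "measured", "known", "first", "only" and "open" are said of these compounds alone.

Compound 1 `O=C(O)c1csc(SCCN2C(=O)CC[C@@H]2/C=C/[C@@H](O)Cc2cccc(-c3ccc(Cl)cc3)c2)n1` gives 260 nM
Compound 2 `O=C(O)c1csc(SCCN2C(=O)CC[C@@H]2/C=C/[C@@H](O)Cc2cccc(-c3nc4ccccc4o3)c2)n1` gives 1600 nM

In a functional assay on CHO cells for agonist activity at prostaglandin E2 receptor EP2 subtype (Rattus norvegicus), read by cAMP accumulation and immunoassay, with a stated time of 10 min (a higher number here means that more compound is needed for the effect, a lower number that less compound is needed), compound 2 gives the highest of the two numbers. Among the compounds with values here, the one measured step, a 6.2-fold higher number from compound 1 to compound 2 (0.79 log units; beyond the scatter), lies beyond the scatter. Compound 3 `Cc1cccc2oc(-c3cccc(C[C@H](O)/C=C/[C@H]4CCC(=O)N4CCSc4nc(C(=O)O)cs4)c3)nc12` differs from compound 2 by methyl in place of hydrogen on an aromatic carbon. Within the data shown here, no measured step involves a methyl in place of hydrogen, and the step between compound 1 and compound 2 swaps a whole ring group, so it does not bear on this change. With nothing to go on, the expected step of no change at the digits printed from compound 2 to compound 3 (within the scatter) is none beyond the scatter. Compound 3 is therefore estimated at 1600 nM, between 500 nM and 5000 nM.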

Compound 3, half-maximal effective concentration: 8500 nM
Estimate against measurement, compound 3: 5.3-fold (0.73 log units) below; the measured number lies above the stated range.
By their numbers in this assay, from the lowest: compound 1; then compound 2; then compound 3.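

In this assay, adding one methyl to give 4-methyl-1,3-benzoxazol-2-yl brings a 5.3-fold higher number from compound 2 to compound 3 (0.73 log units; beyond the scatter) and so is not a silent change on this six-membered aromatic ring. Against the 4-chlorophenyl group, the methylated ring gives a 33-fold higher number from compound 1 to compound 3 (1.51 log units; beyond the scatter) and this large step exceeds the modest one seen for the unsubstituted benzoxazole. Nothing measured here explains the methyl step.

Going by these compounds, it remains open whether the methyl on another carbon of this ring would give the same result. On these data alone, it is also open how an ethyl, a methoxy or an amine would behave in its place.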